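Thioether substituent variation on the shared core

A few compounds are considered here, and "the series" means these few. Any claim that something is new, unique, unknown or untested is made for them only; others in the source may bear on it.

Compound 1 `CSc1nc(NCc2ccc(-c3ccccn3)cc2)c2[nH]nc(C(C)C)c2n1` gives 783 nM in a functional assay on HT cells (Homo sapiens) for antiproliferative activity, read by fluorescence, with a stated time of 72 h (on this read-out lower numbers stand for stronger inhibition of growth and higher numbers for weaker inhibition of growth), the highest of the three numbers in hand. Compound 2 `CC(C)c1n[nH]c2c(NCc3ccc(-c4ccccn4)cc3)nc(SCCN)nc12` gives 22 nM, and compound 3 `CC(C)c1n[nH]c2c(NCc3ccc(-c4ccccn4)cc3)nc(SC3CCCCC3N)nc12` gives 139 nM. Both measured changes at the sulfur lowered the number: a 36-fold lower number from compound 1 to compound 2 (1.55 log units; beyond the scatter) and a 5.6-fold lower number from compound 1 to compound 3 (0.75 log units; beyond the scatter); between the two, a 6.3-fold higher number from compound 2 to compound 3 (0.80 log units; beyond the scatter). Compound 4 `CCC(CO)Sc1nc(NCc2ccc(-c3ccccn3)cc2)c2[nH]nc(C(C)C)c2n1` differs from compound 1 as follows: 1-(hydroxymethyl)propyl in place of methyl on a sulfur. This again enlarges the group on the sulfur, as in the two measured steps, yet neither of those brings in a 1-(hydroxymethyl)propyl, so only the direction, not the size, is borrowed. A modest lowering of the number is expected, a 2.2-fold lower number from compound 1 to compound 4 (0.35 log units; beyond the scatter). Compound 4 is therefore estimated at 350 nM, within a range of 120 nM to 1000 nM.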

Compound 4, concentration for 50% growth inhibition: 255 nM
The estimate for compound 4 lay 1.4-fold (0.14 log units) above the measured number, and the stated range covers the measured number.
By their numbers in this assay, from the lowest: compound 2; then compounds 3 and 4 (each within the scatter of the next); then compound 1.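

Replacing methyl on the sulfur with 1-(hydroxymethyl)propyl still lowers the number (a 3.1-fold lower number from compound 1 to compound 4 (0.49 log units; beyond the scatter)), so a group without an amine can do this at this position. That group cannot be told apart from 2-aminocyclohexyl (a 1.8-fold higher number from compound 3 to compound 4 (0.26 log units; within the scatter)), while the step from 2-aminoethyl is large (a 12-fold higher number from compound 2 to compound 4 (1.06 log units; beyond the scatter)). No supporting data bear on the cause of these steps. Still open, going by these compounds, is whether the result for compound 2 depends on its amine or its chain: 2-hydroxyethyl and a longer aminoalkyl chain on the sulfur would separate the two.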